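Trifluoromethyl for Methyl on the Core of Compound 1

A few compounds are considered here, and "the series" means these few. Any claim that something is new, unique, unknown or untested is made for them only; others in the source may bear on it.

Compound 1 `Cc1nc(N(C)C(=O)NC(=O)c2c(F)cccc2F)sc1C(=O)N/N=C/c1ccc(C(F)(F)F)cc1` is one of three compounds with a shared core tested in a functional assay on HepG2 cells (Homo sapiens) for inhibition, read by MTT assay, with a stated time of 72 h; a lower number here means a stronger inhibitor, a higher number a weaker inhibitor. In this assay compound 1 gives > 100 ug/mL, which is a limit of the assay and not a number. Compound 2 `Cc1nc(N(C)C(=O)NC(=O)c2c(F)cccc2F)sc1C(=O)N/N=C/c1ccccc1F` gives > 100 ug/mL, again a limit. Compound 3 `COc1ccc(/C=N/NC(=O)c2sc(N(C)C(=O)NC(=O)c3c(F)cccc3F)nc2C)cc1` gives 22.7 ug/mL. All measured steps concern the aryl group on the carbon with a double bond to nitrogen: a step that the two limits leave unreadable from compound 1 to compound 2; an at least 4.4-fold lower number from compound 1 to compound 3 (0.64 log units; beyond the scatter); an at least 4.4-fold lower number from compound 2 to compound 3 (0.64 log units; beyond the scatter). Compound 1 thus stands at the limit of > 100 ug/mL in this assay, at which 2 of the 3 values shown sit.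

Compound 4 `CN(C(=O)NC(=O)c1c(F)cccc1F)c1nc(C(F)(F)F)c(C(=O)N/N=C/c2ccc(C(F)(F)F)cc2)s1` differs from compound 1 on the core itself: trifluoromethyl in place of methyl on an aromatic carbon. Within the data shown here, no measured step touches this position, so none speaks directly to the change. Among the measured compounds shown here, what carries over is only that compound 1 sits at the limit, so compound 4 is expected to stay near it, the expected step being a number no higher from compound 1 to compound 4 (the limit leaves the size open), in neither direction beyond the scatter. Compound 4 is estimated at 100 ug/mL, between 30 ug/mL and 300 ug/mL, most likely reported again as a limit.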

Compound 4, half-maximal inhibitory concentration: 49.6 ug/mL
Compound 4: middle estimate off by 2.0-fold (0.30 log units), on the high side; the measured number falls inside the stated range.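

Among these compounds, the position on the core, which no earlier step touched, now has a measured step in this assay: trifluoromethyl in place of methyl on this aromatic carbon gives an at least 2.0-fold lower number from compound 1 to compound 4 (0.30 log units; that floor lies within the scatter). This shows that the aryl group is not the only part of the structure that can move a compound off the limit, as compound 4 keeps the 4-(trifluoromethyl)phenyl group of compound 1 and still gives a readable number. The true size of the step cannot be told, and its floor alone does not clear the scatter, because the value of compound 1 is a limit of the assay and not a number: the limit of > 100 ug/mL in this assay, at which 2 of the 4 values shown sit.

From the compounds shown here alone, whether the same change on the core would act alike with the 2-fluorophenyl or 4-methoxyphenyl group stays open. Only methyl and trifluoromethyl are shown at this position, so what an ethyl group, a longer chain or an amine would give there also remains unknown.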